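The compounds below may be only part of what the source reports. "The series", "measured", "known", "first", "only" and "open" are said of these compounds alone.

Measured in an ADME assay (liver) for metabolic stability, with Liver microsome (Rattus norvegicus) as the target, using microsomes; on this read-out higher numbers stand for fast clearance and lower numbers for slow clearance:
- Compound 1 `O=C(O)c1csc(-n2nc(-c3cccc(F)c3)c3ccccc32)n1`: 385 mL/min/kg
- Compound 2 `COc1ccc(-c2nn(-c3nc(C(=O)O)cs3)c3ccccc23)cc1`: 618 mL/min/kg
- Compound 3 `O=C(O)c1csc(-n2nc(C3=CCCCC3)c3ccccc32)n1`: 490 mL/min/kg

Compound 3 gives 490 mL/min/kg, and its two links to the others, a 1.3-fold higher number from compound 1 to compound 3 (0.10 log units; within the scatter) and a 1.3-fold lower number from compound 2 to compound 3 (0.10 log units; within the scatter), leave it indistinguishable from them. Compound 4 `O=C(O)c1csc(-n2nc(N3CCCCC3)c3ccccc32)n1` carries piperidin-1-yl in place of cyclohex-1-en-1-yl on an aromatic carbon. The three measured steps all swap the group on this same carbon, and the remaining one, a 1.6-fold higher number from compound 1 to compound 2 (0.21 log units; within the scatter), is also small. Within the data shown here, none of the measured compounds has piperidin-1-yl there, so this is an extrapolation. No change beyond the scatter is expected in this assay. The expected change is a 1.0-fold lower number from compound 3 to compound 4 (0.02 log units; within the scatter). The estimate for compound 4 is 470 mL/min/kg, with an expected range from 230 mL/min/kg to 950 mL/min/kg.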

Compound 4, clearance: 139 mL/min/kg
Compound 4: the middle estimate sits 3.4-fold (0.53 log units) above what was measured; measured number below the stated range.
By their numbers in this assay, from the lowest: compound 4; then compounds 1, 3 and 2 (each within the scatter of the next).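

Three groups on this carbon gave numbers within the scatter of one another in this assay, but piperidin-1-yl moves the number beyond it, with a 3.5-fold lower number from compound 3 to compound 4 (0.55 log units; beyond the scatter) and a 4.4-fold lower number from compound 2 to compound 4 (0.65 log units; beyond the scatter) and a 2.8-fold lower number from compound 1 to compound 4 (0.44 log units; beyond the scatter). Compared with cyclohex-1-en-1-yl, piperidin-1-yl keeps the six-membered ring but brings a ring nitrogen and loses the double bond, and compound 3 and compound 4 cannot separate these two differences. Nothing measured here explains the lower number.

On these data alone, it remains open whether cyclohexyl, an all-carbon ring without the double bond, would give a number like that of compound 3 or compound 4. Other amines on this carbon, such as morpholin-4-yl or an open-chain diethylamino group, also remain open.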